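Removing a Methoxy from the Best Measured Compound

The compounds below may be only part of what the source reports. "The series", "measured", "known", "first", "only" and "open" are said of these compounds alone.

Compound 1 `COc1ccccc1/C=C/C(=O)/C=C/c1ccc(OCc2cn(CCCOc3cc(=O)oc4ccccc34)nn2)c(OC)c1`: 53%
Compound 2 `COc1ccc(/C=C/C(=O)/C=C/c2ccc(OCc3cn(CCCOc4cc(=O)oc5ccccc45)nn3)c(OC)c2)cc1OC`: 67%

Both values come from a functional assay on HCT-116 cells (Homo sapiens) for inhibition, read by sulforhodamine B assay, with a stated time of 48 h, tested at 50 uM; on this read-out higher numbers stand for more inhibition of growth at the one concentration tested and lower numbers for less inhibition of growth. Among the compounds with values here, compound 2 stands highest of the two at 67%, clear of its only neighbour on the scale. The next compound is compound 3 `COc1ccc(/C=C/C(=O)/C=C/c2ccc(OCc3cn(CCCOc4cc(=O)oc5ccccc45)nn3)c(OC)c2)cc1`, in which the 3,4-dimethoxyphenyl of compound 2 becomes 4-methoxyphenyl: hydrogen in place of methoxy on an aromatic carbon. This places hydrogen on an aromatic carbon, ortho to a methoxy group, where a methoxy stood before.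

Within the data shown here, only one measured step bears on this change: a number 14 percentage points higher from compound 1 to compound 2 (beyond the scatter). Among the measured compounds shown here, that step concerns the same group, exchanging 2-methoxyphenyl for 3,4-dimethoxyphenyl, but no measured pair isolates the removal of this methoxy alone. Compound 3 would return to a methoxyphenyl group, as in compound 1, which gives 53%. A modest drop is therefore expected, smaller than the measured step and possibly within the scatter. The expected step is a number 7 percentage points lower from compound 2 to compound 3 (within the scatter). Compound 3 is estimated at 60% in this assay, with an expected range of 48% to 71%.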

Compound 3, percent growth inhibition at one concentration: 54%
For compound 3 the middle estimate is 6 percentage points above the measured one; measured number inside the range.
By their numbers in this assay, from the lowest: compounds 1 and 3 (each within the scatter of the next); then compound 2.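

In this assay the exchange of this methoxy for hydrogen, ortho to a methoxy group, gives a number 13 percentage points lower from compound 2 to compound 3 (beyond the scatter) and so shows that this single group carries a step larger than the scatter, something that the earlier pair could not isolate. The second comparison gives a number 1 percentage points higher from compound 1 to compound 3 (within the scatter) and so shows that 2-methoxyphenyl and 4-methoxyphenyl cannot be told apart on this read-out, which leaves compound 2 with its 3,4-dimethoxyphenyl as the only one of the three set clear of the others. Among these three compounds, the higher number goes with the presence of both methoxy groups on the ring rather than with where a lone methoxy sits, and no measurement shown here explains why.

What the compounds leave open is whether methoxy itself is needed on that aromatic carbon, or whether a hydroxy, an ethoxy, a fluorine or an amine in the same place would hold the number of compound 2. Going by these compounds, it is also open whether the step seen at this one concentration would persist across a full range of concentrations, or on cell lines other than this one.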